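A few compounds are considered here, and "the series" means these few. Any claim that something is new, unique, unknown or untested is made for them only; others in the source may bear on it.

Measured compounds:
compound 1 `CCOc1ccc2nc(Cl)c(/C=N/NC(=O)c3cc4cc(Br)ccc4oc3=O)cc2c1` — 29000 nM
compound 2 `O=C(N/N=C/c1ccncc1)c1cc2ccccc2oc1=O` — 17200 nM

In a functional assay on HepG2 cells (Homo sapiens) for antiproliferative activity, read by fluorescence and resazurin assay, with a stated time of 48 h (a higher number here means a weaker inhibitor, a lower number a stronger inhibitor), compound 1 gives 29000 nM, and compound 2 gives 17200 nM; the two numbers sit within the scatter of each other, so neither can be set above the other. Compound 3 `O=C(N/N=C/c1cc2ccccc2nc1Cl)c1cc2cc(Br)ccc2oc1=O` is not yet measured in this assay. It differs from compound 1 by hydrogen in place of ethoxy on an aromatic carbon, with hydrogen in place of ethoxy on an aromatic carbon. For the measured compounds named here, no step between measured compounds bears on this change, so the step from compound 1 to compound 3 is expected to stay within the scatter, in no fixed direction: a 1.0-fold higher number from compound 1 to compound 3 (0.01 log units; within the scatter). Compound 3 is estimated at 30000 nM, between 10000 nM and 90000 nM.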

Compound 3, half-maximal inhibitory concentration: 9420 nM
Compound 3: middle estimate off by 3.2-fold (0.50 log units), on the high side; measured number below the stated range.
By their numbers in this assay, from the lowest: compounds 3, 2 and 1 (each within the scatter of the next, the first and the last beyond it).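

In this assay, hydrogen in place of ethoxy on an aromatic carbon gives a 3.1-fold lower number from compound 1 to compound 3 (0.49 log units; beyond the scatter), a modest step beyond the scatter. For the compounds shown here, it is the first single change with a readable effect, and it shows that this position responds to substitution and that the ethoxy is not needed for the activity of compound 1, since the number falls without it.

On these data alone, whether a methoxy, a longer chain or an amine on this carbon would read nearer compound 1 or compound 3 remains open. Nothing measured here gives a cause for the step.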